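The source may report more compounds than this note shows. Statements on the series, on what has been measured and on what is new or still open speak of the compounds shown alone.

Measured compounds:
compound 1, `Cc1noc(C)c1-c1cnc(N)c(Oc2ccc(C(=O)NC3CC3)cc2)n1`, 17800 nM
compound 2, `Cc1noc(C)c1-c1cnc(N)c(Oc2ccc(C(=O)Nc3ccc(Cl)cc3)cc2)n1`, 2230 nM
compound 3, `Cn1cc(-c2cnc(N)c(Oc3ccc(C(=O)Nc4ccc(Cl)cc4)cc3)n2)cn1`, 3440 nM

The three compounds share a core and differ at two places: the group on the amide-type nitrogen and the aromatic group on the core. In a functional assay on HeLa cells (Homo sapiens) for inhibition, read by MTT assay, with a stated time of 72 h (on this read-out lower numbers stand for stronger inhibition and higher numbers for weaker inhibition), compound 1 gives 17800 nM, compound 2 gives 2230 nM and compound 3 gives 3440 nM. Compound 3 thus holds the second highest of the three numbers; its nearest neighbour is compound 2, and its furthest is compound 1.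

Two steps have been measured. The change an 8.0-fold lower number from compound 1 to compound 2 (0.90 log units; beyond the scatter) was the larger one, and the change a 1.5-fold higher number from compound 2 to compound 3 (0.19 log units; within the scatter) stayed within the scatter.

Compound 4, `Cn1cc(-c2cnc(N)c(Oc3ccc(C(=O)Nc4cc(Cl)ccn4)cc3)n2)cn1`, is not yet measured. It differs from compound 3 by 4-chloropyridin-2-yl in place of 4-chlorophenyl on an amide-type nitrogen. Among the measured compounds shown here, of the measured steps, only the one from compound 1 to compound 2 touches the same amide-type nitrogen, and that step swapped a non-aromatic group for an aromatic one, which is a different kind of change; here one six-membered aromatic ring replaces another. For the measured compounds named here, no measured step shows the effect of adding one hetero atom into that ring. The expectation is therefore a step of a 1.0-fold higher number from compound 3 to compound 4 (0.01 log units; within the scatter) in this assay, that is, no change beyond the scatter. Compound 4 is estimated at 3500 nM, with a range from 1400 nM to 9000 nM.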

Compound 4, half-maximal inhibitory concentration: 40800 nM
Compound 4: the middle estimate sits 12-fold (1.07 log units) below what was measured, and the stated range ends below it.
By their numbers in this assay, from the lowest: compounds 2 and 3 (each within the scatter of the next); then compound 1; then compound 4.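

In this assay, the swap of 4-chlorophenyl for 4-chloropyridin-2-yl on the amide-type nitrogen gives a 12-fold higher number from compound 3 to compound 4 (1.07 log units; beyond the scatter), so this position responds strongly to a change within the ring itself, although the entering group has the same count of heavy atoms and differs by one ring nitrogen and one hydrogen-bond acceptor. The earlier step at this nitrogen, an 8.0-fold lower number from compound 1 to compound 2 (0.90 log units; beyond the scatter), replaced a non-aromatic group with an aromatic ring and showed only that 4-chlorophenyl gives a lower number than cyclopropyl, whereas the new step shows that one six-membered aromatic ring cannot simply stand in for another here. Nothing at hand explains the size of this step.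

Whether the swap has a similar effect with 3,5-dimethyl-1,2-oxazol-4-yl on the core remains open, as the step is shown only with 1-methyl-1H-pyrazol-4-yl there. Also open, from the compounds shown here alone, is whether a 4-fluorophenyl or 4-methoxyphenyl group on the same nitrogen would stay within the scatter of compound 3 at 3440 nM, and what the chlorine itself contributes at this position.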